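This account rests on a few compounds, and the source may have more. Where it says the series, first, only, none or still open, it means among the compounds named here.

Measured compounds:
- compound 1, `CC(C)(C)[C@@H](O)C(=O)N1C[C@@H]2C[C@@H]2[C@H]1C(=O)NCc1cc(Cl)ccc1-n1cnnn1`, 17 10^-6 cm/s
- compound 2, `CC(C)(C)OC[C@@H](O)C(=O)N1C[C@@H]2C[C@@H]2[C@H]1C(=O)NCc1cc(Cl)ccc1-n1cnnn1`, 17 10^-6 cm/s

Both compounds were run in an ADME assay on Caco-2 cells (Homo sapiens) for permeability, read by LC-MS, in the apical to basolateral direction, with a stated time of 60 min, at pH 6.5; a lower number here means that the compound crosses the layer more slowly, a higher number that the compound crosses the layer faster. Compound 2 stands level with compound 1 at the digits shown, and the single measured step, no change at the digits printed from compound 1 to compound 2 (within the scatter), lies within the scatter of the method. Compound 2 is therefore the nearest measured neighbour of the next compound, and it gives no sign that the group on that carbon shifts the permeability reading either way.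

Compound 3, `O=C(NCc1cc(Cl)ccc1-n1cnnn1)[C@@H]1[C@H]2C[C@H]2CN1C(=O)[C@H](O)C1CCCCC1`, differs from compound 2 at the same place: cyclohexyl in place of (tert-butoxy)methyl on a saturated chain carbon bound to a carbonyl carbon and an oxygen on a saturated carbon. For the measured compounds named here, the only measured step that bears on this position is no change at the digits printed from compound 1 to compound 2 (within the scatter), which was flat. Nothing measured separates the cyclohexyl group from the groups already tried there, so the expectation rests on that flat step alone, and the step from compound 2 to compound 3 is expected to stay within the scatter, no change at the digits printed from compound 2 to compound 3 (within the scatter). On that basis compound 3 is estimated at 17 10^-6 cm/s in this assay, with a range from 9 10^-6 cm/s to 32 10^-6 cm/s.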

Compound 3, apparent permeability: 25 10^-6 cm/s
For compound 3 the middle estimate is 1.5-fold (0.17 log units) below the measured one; the measured number falls inside the stated range.
By their numbers in this assay, from the lowest: compounds 1, 2 and 3 (each within the scatter of the next).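

In this assay, the place on a saturated chain carbon bound to a carbonyl carbon and an oxygen on a saturated carbon now carries a ring, and cyclohexyl stays in line with both open groups (a 1.5-fold higher number from compound 2 to compound 3 (0.17 log units; within the scatter); a 1.5-fold higher number from compound 1 to compound 3 (0.17 log units; within the scatter)). The step from (tert-butoxy)methyl exchanges a group with no ring and 1 hydrogen-bond acceptor for one six-membered non-aromatic ring of carbon only with 0 hydrogen-bond acceptors, at 6 heavy atoms on each side, and even this exchange remains within the scatter, so the three groups shown are not separated at this place. Nothing available accounts for this agreement among the three compounds.

The compounds shown leave open whether this place would tolerate an amine, a carboxylic acid, a phenyl ring or a group as small as methyl in the same way, since all three groups here are neutral and made up of saturated carbon, with a single ether oxygen in one. They also leave open how the reading responds to changes elsewhere, such as replacing the chlorine or the tetrazole on the shared core. Every compound shown carries these unchanged.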